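Vinyl to phenyl swap carried across two cores

The source may report more compounds than this note shows. Statements on the series, on what has been measured and on what is new or still open speak of the compounds shown alone.

Measured so far:
Compound 1, `C=CCOCc1cc(-c2cc(Br)ccc2OC)no1`, gives 90400 nM in a functional assay on BV-2 cells (Mus musculus) for inhibition, read by Griess assay, with a stated time of 24 h; on this read-out higher numbers stand for weaker inhibition and lower numbers for stronger inhibition.
Compound 2, `COc1ccc(Br)cc1-c1cc(COCc2ccccc2)on1`, reaches only a limit of this assay, > 200000 nM.
Compound 3, `C=CCn1ccc(-c2cc(Br)ccc2O)n1`, gives 112000 nM in this assay.

Compound 1 and compound 2 differ in one place: phenyl in place of vinyl on a saturated chain carbon bound to an oxygen on a saturated carbon. The step this change makes is an at least 2.2-fold higher number from compound 1 to compound 2 (0.34 log units; beyond the scatter), and it should be read against (the limit of > 200000 nM in this assay, at which 1 of the 3 values shown sits), which is why only a lower bound on the weakening can be stated. Compound 3 and compound 1 lie within the usual scatter of each other in this assay. How the core of compound 3 differs from the core of compound 1 is not broken down here.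

Compound 4, `Oc1ccc(Br)cc1-c1ccn(Cc2ccccc2)n1`, is not yet measured. It relates to compound 3 as compound 2 relates to compound 1: phenyl in place of vinyl on a saturated chain carbon bound to an aromatic nitrogen. The place is not identical, since in compound 1 the saturated chain carbon is bound to an oxygen on a saturated carbon, whereas in compound 3 it is bound to an aromatic nitrogen, so this is the same kind of change rather than the same change.

In this assay the step from compound 3 to compound 4 is expected to be a 2.1-fold higher number from compound 3 to compound 4 (0.31 log units; beyond the scatter), a weakening of similar size to the one seen earlier; this expectation rests on an at least 2.2-fold higher number from compound 1 to compound 2 (0.34 log units; beyond the scatter), with the caveat that the cores differ. Compound 4 is therefore estimated at 230000 nM, with a range expected from 110000 nM to 500000 nM, and a real chance that the assay reports only a limit.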

Compound 4, half-maximal inhibitory concentration: > 200000 nM
Compound 4: a limit, no number (the forecaster's own chance of this, stated with the estimate: 60%); the middle value lies beyond the limit too.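

In this assay, the phenyl for vinyl swap on the core of compound 3 gives an at least 1.7-fold higher number from compound 3 to compound 4 (0.25 log units; that floor lies within the scatter), so this core shows no gain in inhibition from the change, while a weakening beyond the usual scatter is not established here as it is on the core of compound 1. Set beside the earlier step, the result supports carrying the direction of the change no further than this, and a difference in its size between the cores can be neither claimed nor excluded: the same change on two cores in this assay, an at least 2.2-fold higher number (0.34 log units; beyond the scatter) from compound 1 to compound 2 and an at least 1.7-fold higher number (0.25 log units; that floor lies within the scatter) from compound 3 to compound 4; the limit leaves it open whether they differ. Among the compounds shown here, neither step has a known full size, so the data do not show that the change has the same effect on both cores, only that both phenyl compounds end at a limit: the limit of > 200000 nM in this assay, at which 2 of the 4 values shown sit.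

On these data alone, whether an amine or a carboxylic acid in place of the phenyl or vinyl would give a number clear of that limit stays open. As far as these compounds go, the part played by the core alone also stays open: compound 1 and compound 3 differ in more than one place.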